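Swapping the Terminal Amine on Two Related Cores

A few compounds are considered here, and "the series" means these few. Any claim that something is new, unique, unknown or untested is made for them only; others in the source may bear on it.

Compound 1 `CN(C)C12CC(c3ccccc3)C(CN(C(=O)CN3CCCC3)C1)C(c1ccccc1)C2` gives in an ADME assay on L6 cells (Rattus norvegicus) for cytotoxicity, read by resazurin assay, with a stated time of 72 h (a higher number here means a weaker inhibitor, a lower number a stronger inhibitor), a value of 12600 nM. Compound 2 `CN1CCN(CC(=O)N2CC3C(c4ccccc4)CC(N(C)C)(CC3c3ccccc3)C2)CC1` differs from it by 4-methylpiperazin-1-yl in place of pyrrolidin-1-yl on a saturated chain carbon bound to a carbonyl carbon and gives 9250 nM, a step of a 1.4-fold lower number from compound 1 to compound 2 (0.13 log units; within the scatter). Compound 3 `CN(C)C12CC(c3ccccc3)C(CN(CCN3CCCC3)C1)C(c1ccccc1)C2` differs from compound 1 by 2-(pyrrolidin-1-yl)ethyl in place of ((pyrrolidin-1-yl)methyl)carbonyl on an amine nitrogen in a ring. In this assay compound 3 gives 5580 nM, with steps of a 2.3-fold lower number from compound 1 to compound 3 (0.35 log units; beyond the scatter) and a 1.7-fold lower number from compound 2 to compound 3 (0.22 log units; within the scatter). Compound 4 `CN1CCN(CCN2CC3C(c4ccccc4)CC(N(C)C)(CC3c3ccccc3)C2)CC1` is not yet measured; it differs from compound 3 by 4-methylpiperazin-1-yl in place of pyrrolidin-1-yl on a saturated chain carbon, two bonds along the chain from an amine nitrogen in a ring. The surroundings are not identical: in compound 1 the group sits on a saturated chain carbon bound to a carbonyl carbon, whereas in compound 3 it sits on a saturated chain carbon, two bonds along the chain from an amine nitrogen in a ring, so this is the same kind of change rather than the same change. Because the earlier step was a 1.4-fold lower number from compound 1 to compound 2 (0.13 log units; within the scatter), compound 4 is expected to show a step of a 1.3-fold lower number from compound 3 to compound 4 (0.12 log units; within the scatter) in this assay. Compound 4 is therefore estimated at 4200 nM, between 2000 nM and 9000 nM.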

Compound 4, half-maximal inhibitory concentration: 5260 nM
Beside the measured number, compound 4's estimate is 1.3-fold (0.10 log units) below it; measured number inside the range.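

In this assay the exchange of pyrrolidin-1-yl for 4-methylpiperazin-1-yl gives a step on the second core (a 1.1-fold lower number from compound 3 to compound 4 (0.03 log units; within the scatter)), and it compares with the step on the first core as follows: the same change on two cores in this assay, a 1.4-fold lower number (0.13 log units; within the scatter) from compound 1 to compound 2 and a 1.1-fold lower number (0.03 log units; within the scatter) from compound 3 to compound 4, 1.3-fold (0.11 log units) apart, within the scatter of two such steps. The change thus carries over as a step within the scatter on both cores, but one pair per core does not show that it would stay this small on any other core. Replacing the carbonyl-containing chain with 2-(4-methylpiperazin-1-yl)ethyl stays within the scatter from the piperazine amide (a 1.8-fold lower number from compound 2 to compound 4 (0.25 log units; within the scatter)), while the step from the pyrrolidine amide lies beyond it (a 2.4-fold lower number from compound 1 to compound 4 (0.38 log units; beyond the scatter)).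

The compounds shown leave open how another terminal amine, such as morpholin-4-yl or piperidin-1-yl, would behave on these cores. They also leave open the effect of a longer chain to that amine.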